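A few compounds are considered here, and "the series" means these few. Any claim that something is new, unique, unknown or untested is made for them only; others in the source may bear on it.

Going by the values given here, compound 2 `CCCCCCCc1ccc(NC(=O)Nc2c(C(C)C)cccc2C(C)C)cc1` gives 19 nM in an assay on isolated protein for inhibition of acyl-CoA:cholesterol acyltransferase (Oryctolagus cuniculus); a lower number here means a stronger inhibitor, a higher number a weaker inhibitor; of the two numbers known, it stands at the upper one, with compound 1 `CCCCCCCCc1ccc(NC(=O)Nc2c(C(C)C)cccc2C(C)C)cc1` at 11 nM lying within the scatter of it. Among the compounds with values here, the one measured step, a 1.7-fold higher number from compound 1 to compound 2 (0.24 log units; within the scatter), removed a methyl seven bonds along the chain from an aromatic carbon. Compound 3 `CCCCc1ccc(NC(=O)Nc2c(C(C)C)cccc2C(C)C)cc1` carries the change (hydrogen in place of propyl on a saturated chain carbon, four bonds along the chain from an aromatic carbon), a deeper cut into the same chain. Because a 1.7-fold higher number from compound 1 to compound 2 (0.24 log units; within the scatter) was small, only a modest rise is expected in this assay, estimated as a 3.2-fold higher number from compound 2 to compound 3 (0.50 log units; beyond the scatter). Compound 3 is therefore expected near 60 nM, between 20 nM and 200 nM.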

Compound 3, half-maximal inhibitory concentration: 29 nM
Beside the measured number, compound 3's estimate is 2.1-fold (0.32 log units) above it; the measured number falls inside the stated range.
By their numbers in this assay, from the lowest: compounds 1, 2 and 3 (each within the scatter of the next, the first and the last beyond it).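

In this assay, putting hydrogen in place of propyl, four bonds along the chain from an aromatic carbon, gives a 1.5-fold higher number from compound 2 to compound 3 (0.18 log units; within the scatter), so this shortening alone cannot be told from repeat-measurement noise. Only the larger change, hydrogen in place of butyl at the same place, gives a 2.6-fold higher number from compound 1 to compound 3 (0.42 log units; beyond the scatter), which shows that the chain can lose much of its length at only a modest cost. Nothing measured here explains this behaviour. Still open, from the compounds shown here alone, is whether a methyl, a longer chain, or a chain ending in an amine or a carboxylic acid would hold this level.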